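Amino for chloro on the shared core

The source may report more compounds than this note shows. Statements on the series, on what has been measured and on what is new or still open speak of the compounds shown alone.

Three close analogues share one fused core and differ only in where a chloromethyl group sits on the pendant benzyl ring. Compound 1 `ClCc1ccccc1Cn1cnc2c(Cl)nc(Cl)nc21` gives 1860 nM in a functional assay on 786-0 cells (Homo sapiens) for cytotoxicity, read by sulforhodamine B assay, with a stated time of 48 h (a higher number here means a weaker inhibitor of growth, a lower number a stronger inhibitor of growth), the lowest of the three numbers. Compound 2 `ClCc1ccc(Cn2cnc3nc(Cl)nc(Cl)c32)cc1` gives 1900 nM in this assay, a value that lies within the scatter of compound 1. Compound 3 `ClCc1cccc(Cn2cnc3c(Cl)nc(Cl)nc32)c1` gives 12300 nM in this assay, which stands beyond the scatter above compound 1.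

The untested compound 4 `Nc1nc(Cl)c2ncn(Cc3ccccc3CCl)c2n1` keeps the benzyl substitution of compound 1 and changes the core: amino in place of chloro on an aromatic carbon between two ring nitrogen atoms. Within the data shown here, no measured pair among the three shows this exchange, so the size of the step cannot be read from the numbers at hand; the step is expected to be moderate and directed toward a higher number, so toward weaker growth inhibition. On that basis compound 4 is estimated at 5000 nM in this assay, within a range from 1500 nM to 20000 nM, which corresponds to an expected step of a 2.7-fold higher number from compound 1 to compound 4 (0.43 log units; beyond the scatter).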

Compound 4, concentration for 50% growth inhibition: 17000 nM
Estimate against measurement, compound 4: 3.4-fold (0.53 log units) below; the range from low to high includes it.
By their numbers in this assay, from the lowest: compounds 1 and 2 (each within the scatter of the next); then compounds 3 and 4 (each within the scatter of the next).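

In this assay, amino in place of chloro on an aromatic carbon between two ring nitrogen atoms gives a 9.1-fold higher number from compound 1 to compound 4 (0.96 log units; beyond the scatter). Among these compounds, the earlier compounds varied only the chloromethyl group on the benzyl ring, so this is the first sign that growth inhibition also responds to what this position of the shared core carries, here moving toward weaker inhibition with the benzyl substitution held fixed. Nothing at hand accounts for the size or direction of this step.

From the compounds shown here alone, it remains open whether a methylamino group, a methoxy group or plain hydrogen at this position would stay closer to the chloro compound. Going by these compounds, it is also open whether the same exchange would give a similar step with the chloromethyl group placed as in compound 2 or compound 3.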